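The source may hold more compounds than are shown below. What is called first, only, known or untested is meant among the compounds shown, and "the series" means these compounds.

Compound 1 `Oc1ccc(-c2nc3ccccc3s2)cc1O` carries two hydroxyl groups on the ring that is joined to the shared core, and in a functional assay on KM12 cells (Homo sapiens) for antiproliferative activity (on this read-out higher numbers stand for weaker inhibition of growth and lower numbers for stronger inhibition of growth), compound 1 gives 15600 nM. Compound 3 `Oc1ccc(-c2nc3cc(F)ccc3s2)cc1O` keeps both hydroxyl groups and adds a fluorine to the core: the change is fluoro in place of hydrogen on an aromatic carbon, and in this assay compound 3 gives 13000 nM. The step of a 1.2-fold lower number from compound 1 to compound 3 (0.08 log units; within the scatter) is thus small. Compound 2 `COc1ccc(-c2nc3ccccc3s2)cc1OC` has both hydroxyl groups replaced by methoxy groups, and in this assay compound 2 gives 74200 nM; the difference between the cores of compound 1 and compound 2 is not broken down here, but the values show compound 2 standing beyond the scatter from both compound 1 and compound 3.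

Compound 4 `COc1ccc(-c2nc3c(F)cccc3s2)cc1OC` has not yet been measured in this assay. For the measured compounds named here, it differs from compound 2 by fluoro in place of hydrogen on an aromatic carbon, the same kind of change as the one from compound 1 to compound 3, though the place is not identical: in compound 3 the fluorine sits meta to a fused ring and para to a fused ring, whereas in compound 4 it sits ortho to a fused ring and meta to a fused ring. Going by the values given here, because the one measured example of this change, a 1.2-fold lower number from compound 1 to compound 3 (0.08 log units; within the scatter), stayed within the scatter, the step from compound 2 to compound 4 is expected to be likewise small, about a 1.1-fold lower number from compound 2 to compound 4 (0.06 log units; within the scatter). On that basis compound 4 is estimated to give 65000 nM in this assay, expected to fall between 30000 nM and 150000 nM.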

Compound 4, concentration for 50% growth inhibition: 850 nM
Compound 4: the middle estimate sits 76-fold (1.88 log units) above what was measured; measured number below the stated range.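

In this assay, fluoro in place of hydrogen on an aromatic carbon brings an 87-fold lower number from compound 2 to compound 4 (1.94 log units; beyond the scatter), a large step. The size of this change therefore does not carry from one core to the other in this series: the same change on two cores in this assay, a 1.2-fold lower number (0.08 log units; within the scatter) from compound 1 to compound 3 and an 87-fold lower number (1.94 log units; beyond the scatter) from compound 2 to compound 4, 73-fold (1.86 log units) apart, beyond the scatter of two such steps What this does not show is which difference between the two pairs goes with the gap: one pair carries two hydroxyl groups and the other two methoxy groups, and the fluorine sits meta to a fused ring and para to a fused ring in compound 3 but ortho to a fused ring and meta to a fused ring in compound 4, so the two steps alone cannot separate these differences.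

Left open is whether fluoro at the place it holds in compound 4 would bring a similar step on the core of compound 1, and whether fluoro at the place it holds in compound 3 would do so on the core of compound 2. Also open, from the compounds shown here alone, is whether another group at the place of the fluorine in compound 4, such as chloro or an amine, would give a number close to that of compound 4.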